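A few compounds are considered here, and "the series" means these few. Any claim that something is new, unique, unknown or untested is made for them only; others in the source may bear on it.

Three compounds share one core and differ only in the aromatic group attached to the three-membered ring. In a functional assay for agonist activity at G protein-coupled receptor 88 (Homo sapiens), read by HTRF and cAMP accumulation (on this read-out higher numbers stand for an effect only at larger amounts of compound and lower numbers for an effect already at smaller amounts), compound 3 `CC[C@H](C)[C@H](N)CN(C(=O)[C@@H]1C[C@H]1c1ccoc1)c1ccc(-c2ccccc2)cc1` gives 580 nM, and compound 2 `CC[C@H](C)[C@H](N)CN(C(=O)[C@@H]1C[C@H]1c1ccc(F)cc1)c1ccc(-c2ccccc2)cc1` gives 600 nM; these two stand together at the low end, since a 1.0-fold lower number from compound 2 to compound 3 (0.01 log units; within the scatter). Compound 1 `CC[C@H](C)[C@H](N)CN(C(=O)[C@@H]1C[C@H]1c1ccc(Cl)cc1)c1ccc(-c2ccccc2)cc1` gives 4300 nM, clearly apart: a 7.2-fold lower number from compound 1 to compound 2 (0.86 log units; beyond the scatter) and a 7.4-fold lower number from compound 1 to compound 3 (0.87 log units; beyond the scatter). Compound 4 `CC[C@H](C)[C@H](N)CN(C(=O)[C@@H]1C[C@H]1c1ncc(C)s1)c1ccc(-c2ccccc2)cc1` differs from compound 3 by 5-methyl-1,3-thiazol-2-yl in place of furan-3-yl on a saturated ring carbon. Among the measured compounds shown here, the one earlier exchange of one aromatic group for another at this ring carbon moved the number hardly at all, so for compound 4 little beyond the scatter is expected, a 1.3-fold higher number from compound 3 to compound 4 (0.11 log units; within the scatter). Compound 4 is thus estimated at 750 nM, with a range from 250 nM to 2500 nM.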

Compound 4, half-maximal effective concentration: 1300 nM
Compound 4: the middle estimate sits 1.7-fold (0.24 log units) below what was measured; low and high end bracket the measured number.
By their numbers in this assay, from the lowest: compounds 3 and 2 (each within the scatter of the next); then compound 4; then compound 1.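

In this assay, exchanging one aromatic group for another at this ring carbon need not leave the number unchanged: there is a 2.2-fold higher number from compound 3 to compound 4 (0.35 log units; beyond the scatter) and a 2.2-fold higher number from compound 2 to compound 4 (0.34 log units; beyond the scatter) when 5-methyl-1,3-thiazol-2-yl enters. The same group still compares well with 4-chlorophenyl, with a 3.3-fold lower number from compound 1 to compound 4 (0.52 log units; beyond the scatter) at this position, so the four groups fall at three distinct levels. Nothing available explains this order.

Still open, on these data alone, is how the plain 1,3-thiazol-2-yl group without its methyl would read, which would separate the effect of the ring from that of the methyl. A furan-3-yl carrying a methyl or an amine would test the same question from the other side.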